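Nitro to methyl on compound 3

The compounds below may be only part of what the source reports. "The series", "measured", "known", "first", "only" and "open" are said of these compounds alone.

In a functional assay on MDA-MB-231 cells (Homo sapiens) for cytotoxicity, read by MTT assay, with a stated time of 48 h (a higher number here means a weaker inhibitor, a lower number a stronger inhibitor), compound 1 (`Nc1ccc(NC(=O)NCCCCC(c2ccc(F)cc2)c2ccc(F)cc2)cc1`) returns > 20000 nM which is a limit and not a number. Compound 2 (`O=C(NCCCCC(c1ccc(F)cc1)c1ccc(F)cc1)Nc1ccc(C(F)(F)F)cc1`) gives 2780 nM and compound 3 (`O=C(NCCCCC(c1ccc(F)cc1)c1ccc(F)cc1)Nc1cccc([N+](=O)[O-])c1`) gives 3790 nM so compound 3 has a measured neighbour in compound 2. The gap between them is a 1.4-fold higher number from compound 2 to compound 3 (0.13 log units; within the scatter) and counts as no real difference.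

Compound 4 (`Cc1cccc(NC(=O)NCCCCC(c2ccc(F)cc2)c2ccc(F)cc2)c1`) carries methyl in place of nitro on an aromatic carbon and is otherwise the same as compound 3. Going by the values given here, no measured step covers this exact exchange, so the neighbouring steps must serve as a guide. Replacing nitro-bearing compound 3 with trifluoromethyl-bearing compound 2 made no difference beyond the scatter. The large steps both start at the amino-bearing compound 1, namely an at least 7.1-fold lower number from compound 1 to compound 2 (0.85 log units; beyond the scatter) and an at least 5.2-fold lower number from compound 1 to compound 3 (0.72 log units; beyond the scatter) and these go against any idea that the group here never matters. Methyl is not amino, so compound 4 is expected to stay nearer compound 3 than compound 1, though with real uncertainty. The estimated step is a 1.3-fold higher number from compound 3 to compound 4 (0.12 log units; within the scatter) so no change beyond the scatter is expected. Compound 4 is estimated at 5000 nM with an expected range from 2200 nM to 12000 nM.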

Compound 4, half-maximal inhibitory concentration: > 20000 nM
Compound 4: no number, only a limit (the forecaster's own chance of this, stated with the estimate: 10%); middle value at least 4.0-fold (0.60 log units) from the limit.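

Putting methyl in place of nitro at this place on the ring produces an at least 5.2-fold higher number from compound 3 to compound 4 (0.72 log units; beyond the scatter) in this assay, so this single exchange separates a compound with a measurable value from one without. The comparison with the trifluoromethyl compound points the same way, with an at least 7.1-fold higher number from compound 2 to compound 4 (0.85 log units; beyond the scatter), although that pair also differs in where the group sits on the ring. Until now only the amino-bearing compound 1 had failed to give a number, but a compound without amino now does the same, so amino is not the only group tied to this outcome, and compound 4 sits at a limit rather than at a number: the limit of > 20000 nM in this assay, at which 2 of the 4 values shown sit.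

Compound 1 and compound 4 both carry limits, and the step between them cannot be read. The compounds shown also leave open whether a chlorine, a methoxy or a nitrile at this same place would stay with compound 3 or fall with compound 4, and so whether nitro is one of many groups that work here or a rare case.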